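Dithiocarbamate amine size and cytotoxicity in a nitroimidazole series

A few compounds are considered here, and "the series" means these few. Any claim that something is new, unique, unknown or untested is made for them only; others in the source may bear on it.

Measured so far:
compound 1 `Cc1ncc([N+](=O)[O-])n1CC(O)CSC(=S)N1CCCCCC1`: 411000 nM
compound 2 `Cc1ncc([N+](=O)[O-])n1CC(O)CSC(=S)N(C)C`: > 5000000 nM
compound 3 `CCN(C)C(=S)SCC(O)Cn1c([N+](=O)[O-])cnc1C`: 4150000 nM

In a toxicity assay on HeLa cells (Homo sapiens) for cytotoxicity, read by MTT assay, with a stated time of 24 h (on this read-out lower numbers stand for stronger inhibition and higher numbers for weaker inhibition), compound 1 gives 411000 nM. Compound 2 reaches only a limit of this assay, > 5000000 nM, and no number (the limit of > 5000000 nM in this assay, at which 1 of the 3 values shown sits). Compound 3 gives 4150000 nM, the highest of the two numbers shown; its nearest neighbour is compound 1, with a 10-fold higher number from compound 1 to compound 3 (1.00 log units; beyond the scatter). Across the amine on the thiocarbonyl carbon the numbers move widely: an at least 12-fold higher number from compound 1 to compound 2 (1.08 log units; beyond the scatter) and a 10-fold higher number from compound 1 to compound 3 (1.00 log units; beyond the scatter), so the smaller amines sit at the weaker end.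

Compound 4 `CCN(CC)C(=S)SCC(O)Cn1c([N+](=O)[O-])cnc1C` differs from compound 3 by methyl in place of hydrogen on a saturated chain carbon bound to an amide-type nitrogen. Among the measured compounds shown here, the one measured step of the same kind is an at least 1.2-fold lower number from compound 2 to compound 3 (0.08 log units; that floor lies within the scatter), and that gap lies within the scatter, so by itself it predicts no movement. The larger pattern, azepan-1-yl against the two small amines, points toward a lower number as the amine grows, though only compound 1 carries it.

Taking both together, a small step downward is expected, a 1.7-fold lower number from compound 3 to compound 4 (0.22 log units; within the scatter), within or just beyond the scatter. Compound 4 is therefore estimated at 2500000 nM, with a range from 1000000 nM to 6000000 nM.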

Compound 4, half-maximal inhibitory concentration: 2460000 nM
Beside the measured number, compound 4's estimate is 1.0-fold (0.01 log units) above it, within the range that was stated.
By their numbers in this assay, from the lowest: compound 1; then compounds 4 and 3 (each within the scatter of the next). At a limit, above all of these: compound 2.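

Going from ethyl(methyl)amino to diethylamino, methyl in place of hydrogen on a saturated chain carbon bound to an amide-type nitrogen leaves the read-out in this assay within the scatter, a 1.7-fold lower number from compound 3 to compound 4 (0.23 log units; within the scatter), while the distance to azepan-1-yl stays beyond it, a 6.0-fold higher number from compound 1 to compound 4 (0.78 log units; beyond the scatter). Against dimethylamino only a floor can be read, and it lies within the scatter, an at least 2.0-fold lower number from compound 2 to compound 4 (0.30 log units; that floor lies within the scatter). Compound 2 stands at a limit and not at a number: the limit of > 5000000 nM in this assay, at which 1 of the 4 values shown sits.

The open-chain amines shown therefore give no graded trend with added carbon, and azepan-1-yl in compound 1 alone stands clearly apart from compound 3 and compound 4. Going by these compounds, whether that separation belongs to the ring or to the overall size of the amine remains open, and pyrrolidin-1-yl, piperidin-1-yl or dipropylamino on the thiocarbonyl carbon would be the groups to tell these two readings apart.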